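Permeability notes on the step from compound 2 to compound 3

The source may report more compounds than this note shows. Statements on the series, on what has been measured and on what is new or still open speak of the compounds shown alone.

Values so far in an ADME assay for permeability, using PAMPA, at pH 7.4; on this read-out lower numbers stand for lower permeability and higher numbers for higher permeability
compound 1 `O=C(Nc1ccc(F)c(-c2nc3ccccc3s2)c1)c1cc([N+](=O)[O-])ccc1Cl` gives 17 10^-6 cm/s
compound 2 `O=C(Nc1ccc(O)c(-c2nc3ccccc3s2)c1)c1cc([N+](=O)[O-])ccc1Cl` gives "below limit of detection" (no number reported)

Compound 2 stands without a number. For compound 2 the entry "below limit of detection" (no number reported) is not a measured number. Compound 3 `O=C(Nc1cccc(-c2nc3ccccc3s2)c1)c1cc([N+](=O)[O-])ccc1Cl` has not yet been measured. The change hydrogen in place of hydroxy on an aromatic carbon puts hydrogen in place of hydroxy on an aromatic carbon, ortho to a 1,3-benzothiazol-2-yl group. Going by the values given here, no measured step sizes this change. In this assay the expected direction is upward, from no number to a readable number, by more than the scatter. Among the compounds with values here, the only numeric guide is compound 1 at 17 10^-6 cm/s and the expectation rests on that single value. Compound 3 is expected at 15 10^-6 cm/s with an estimated range from 5 10^-6 cm/s to 40 10^-6 cm/s for the coming measurement.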

Compound 3, apparent permeability: 12 10^-6 cm/s
The estimate for compound 3 lay 1.3-fold (0.10 log units) above the measured number; the measured number falls inside the stated range.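

In this assay compound 3 carries a readable number with hydrogen on the aromatic carbon ortho to the 1,3-benzothiazol-2-yl group, while compound 2, with hydroxy there, has no number reported, so the step between these two cannot be read as a size. Hydrogen in place of fluoro on the same carbon gives a 1.4-fold lower number from compound 1 to compound 3 (0.15 log units; within the scatter) and so leaves the two compounds indistinguishable on this read-out, which makes hydroxy the only one of the three groups at this carbon without a number. No supporting measurement bears on the gap between hydroxy and the other two groups.

Going by these compounds, whether a methoxy group or an amine on this carbon gives a readable number remains open. On these data alone, how hydroxy, fluoro and hydrogen compare elsewhere on the shared core also remains open.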